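This account rests on a few compounds, and the source may have more. Where it says the series, first, only, none or still open, it means among the compounds named here.

Measured compounds:

Compound 1 `O=C(Nc1ccc(C(F)(F)F)cc1)c1cc(Br)ccc1O` gives 620 nM in a functional assay on Jurkat cells (Homo sapiens) for cytotoxicity, read by luminescence and CellTiter-Glo, with a stated time of 3 days; on this read-out higher numbers stand for weaker inhibition and lower numbers for stronger inhibition.
Compound 2 `O=C(Nc1cc(F)cc(F)c1)c1ccc2cccnc2c1O` gives 430 nM in this assay.
Compound 3 `N#Cc1ccc(NC(=O)c2cc(Cl)ccc2O)c(Cl)c1` gives 620 nM in this assay.

The three numbers sit close together. Compound 3 is level with compound 1 at the digits shown, with no change at those digits, and its gap to compound 2 is small enough to lie within the scatter as well. On what has been measured so far, nothing separates the three compounds from one another in this assay.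

Compound 4 `O=C(Nc1ccc(OC(F)(F)F)cc1Cl)c1cc(Cl)ccc1O` has not yet been measured in this assay. It differs from compound 3 in one place: trifluoromethoxy in place of cyano on an aromatic carbon

For the measured compounds named here, no step between measured compounds that differ in one place has been recorded, so there is no measured precedent for this exchange within the set. The only relevant point of reference is compound 1, which carries a trifluoromethyl group on the same aryl amide side and gives 620 nM, a number level with compound 3. On that basis no step beyond the scatter is expected for compound 4 in this assay, in either direction.

Compound 4 is therefore expected to give about 600 nM in this assay, with the expected range running from 250 nM to 1500 nM. The step that this estimate means, a 1.0-fold lower number from compound 3 to compound 4 (0.01 log units; within the scatter), is expected to stay within the usual scatter.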

Compound 4, half-maximal inhibitory concentration: 880 nM
Compound 4: the middle estimate sits 1.5-fold (0.17 log units) below what was measured; the range from low to high includes it.
By their numbers in this assay, from the lowest: compounds 2, 1, 3 and 4 (each within the scatter of the next, the first and the last beyond it).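

In this assay, for the compounds shown here, the position para to a large group and meta to a chloro group accepts trifluoromethoxy in place of cyano with a 1.4-fold higher number from compound 3 to compound 4 (0.15 log units; within the scatter), which stays within the scatter and is the only step between compounds differing in one place in this set. This exchange replaces a group of 2 heavy atoms with one of 5 heavy atoms, each counted with 1 hydrogen-bond acceptor and no net charge, so at this position and with the rest of compound 3 held constant, the added size and the loss of the triple bond leave the read-out without a change that can be told from the scatter. No measured information on the compounds shown bears on what lies behind this step.

Open, as far as these compounds go, is how far this position stays so flat when the entering group is of a different kind, such as an amine, a carboxylic acid or a longer chain like butoxy. Also open, from the compounds shown here alone, is whether trifluoromethoxy in place of cyano gives a similar step when the chloro group meta to it is replaced by another group, such as methyl.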